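Notes on adding a second chloro group to compound 2

The source may hold more compounds than are shown below. What is called first, only, known or untested is meant among the compounds shown, and "the series" means these compounds.

Compound 2 `O=C1NC(=S)/C(=C/c2ccccc2Cl)S1` stands second highest of three in a functional assay on HEp-2 cells (Homo sapiens) for cytotoxicity, read by MTT assay, with a stated time of 72 h, tested at 10 ug/mL (on this read-out lower numbers stand for less inhibition of growth and higher numbers for more inhibition of growth at the one concentration tested), where compound 2 gives 21.2%. Compound 1 `O=C1NC(=S)/C(=C/c2ccc(Cl)cc2)S1` gives 22.3% and compound 3 `O=C1NC(=S)/C(=C/c2ccccc2F)S1` gives 11.2%. For the measured compounds named here, the only measured step, a number 10 percentage points lower from compound 2 to compound 3 (within the scatter), stays within the scatter, as does the gap between compound 1 and compound 2. Compound 4 `O=C1NC(=S)/C(=C/c2ccc(Cl)cc2Cl)S1` differs from compound 2 by chloro in place of hydrogen on an aromatic carbon. Going by the values given here, no measured step adds a chloro group to a ring already carrying one; the chloro-to-fluoro step bears on it only loosely, and compound 1 and compound 2 lie close together. Compound 4 is therefore expected to show only a small step, a number 3.8 percentage points higher from compound 2 to compound 4 (within the scatter), not beyond the scatter. Compound 4 is estimated at 25%, in the range 10% to 42%.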

Compound 4, percent growth inhibition at one concentration: 24.8%
The estimate for compound 4 lay 0.2 percentage points above the measured number, within the range that was stated.
By their numbers in this assay, from the lowest: compounds 3, 2, 1 and 4 (each within the scatter of the next, the first and the last beyond it).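

In this assay, for the compounds shown here, a second chloro group gives a number 3.6 percentage points higher from compound 2 to compound 4 (within the scatter) and a number 2.5 percentage points higher from compound 1 to compound 4 (within the scatter) as the first measured steps that add a chloro group to a ring already carrying one. On compound 2 the new group stands meta to a chloro group and para to a group of 8 heavy atoms, and at this place the step stays within the scatter. No supporting data bear on the size of either step.

From the compounds shown here alone, whether an amine or a carboxylic acid at this place would give a step beyond the scatter remains open. So does the effect of a methoxy group there.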